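Methoxy Exchanged for Chloro on the Phenoxy Ring

The compounds below may be only part of what the source reports. "The series", "measured", "known", "first", "only" and "open" are said of these compounds alone.

In a functional assay on MIA PaCa-2 cells (Homo sapiens) for antiproliferative activity, read by MTT assay, with a stated time of 72 h (a lower number here means that less compound is needed, a higher number that more compound is needed for the effect), compound 2 `CNC(=O)c1cccc(Cn2nc(C)c(NC(=O)c3ccc(COc4cccc(OC)c4)cc3)c2C)c1` stands highest of the two numbers at 6200 nM, while compound 1 `CNC(=O)c1cccc(Cn2nc(C)c(NC(=O)c3ccc(COc4ccccc4C)cc3)c2C)c1` gives 2100 nM. Compound 3 `CNC(=O)c1cccc(Cn2nc(C)c(NC(=O)c3ccc(COc4ccccc4Cl)cc3)c2C)c1` is unmeasured; it differs from compound 2 by 2-chlorophenyl in place of 3-methoxyphenyl on an oxygen on a saturated carbon. For the measured compounds named here, only one measured step bears on this change, a 3.0-fold higher number from compound 1 to compound 2 (0.47 log units; beyond the scatter), a modest one in the same place. Since compound 3 carries 2-chlorophenyl, a group resembling the 2-methylphenyl of compound 1 at 2100 nM, a modestly lower number is expected, namely a 2.5-fold lower number from compound 2 to compound 3 (0.39 log units; beyond the scatter). Compound 3 is therefore estimated at 2500 nM, in the range 1000 nM to 6500 nM.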

Compound 3, half-maximal effective concentration: 6300 nM
Beside the measured number, compound 3's estimate is 2.5-fold (0.40 log units) below it, within the range that was stated.
By their numbers in this assay, from the lowest: compound 1; then compounds 2 and 3 (each within the scatter of the next).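

In this assay the exchange of 3-methoxyphenyl for 2-chlorophenyl gives (a 1.0-fold higher number from compound 2 to compound 3 (0.01 log units; within the scatter)), so these two groups are not told apart here. Chloro in place of methyl on an aromatic carbon gives (a 3.0-fold higher number from compound 1 to compound 3 (0.48 log units; beyond the scatter)), so among these three compounds only compound 1, with 2-methylphenyl, stands apart, and the likeness of chloro to methyl does not carry over to the number. No measurement shown here accounts for this result.

On these data alone, whether an ethyl or a trifluoromethyl group in place of that methyl would keep the lower number stays open. So does whether an amine or a carboxylic acid on this ring would shift it.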